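Swapping the Ether Arm for a Carbamoyl Group

A few compounds are considered here, and "the series" means these few. Any claim that something is new, unique, unknown or untested is made for them only; others in the source may bear on it.

Compound 3 `Cc1cc(C)n(CCOC2CC(=O)Nc3c2c(C)nn3-c2ncnc3nc[nH]c23)n1` gives the highest of the three numbers in a functional assay on HEK293 cells for agonist activity at G-protein coupled receptor 39 (Homo sapiens), read by scintillation proximity assay and inositol phosphate accumulation, with a stated time of 75 min, in the presence of a further agent that is not named here (a lower number here means that less compound is needed, a higher number that more compound is needed for the effect), at 16 nM. Compound 1 `Cc1nn(-c2ncnc3nc[nH]c23)c2c1C(c1ccc(F)cc1Cl)CC(=O)N2` gives 9 nM, and compound 2 `Cc1nn(-c2ncnc3nc[nH]c23)c2c1C(OCc1ccccc1Cl)CC(=O)N2` gives 2 nM; the step of a 1.8-fold higher number from compound 1 to compound 3 (0.25 log units; within the scatter) stays within the scatter, while the step of an 8.0-fold higher number from compound 2 to compound 3 (0.90 log units; beyond the scatter) lies beyond it. Compound 4 `Cc1nn(-c2ncnc3nc[nH]c23)c2c1C(C(=O)N(C)c1nccs1)CC(=O)N2` changes the same position: a group of 9 heavy atoms (5 carbon, 2 nitrogen, 1 oxygen, 1 sulfur; one five-membered aromatic ring with 2 hetero atoms) in place of a group of 10 heavy atoms (7 carbon, 2 nitrogen, 1 oxygen; one five-membered aromatic ring with 2 hetero atoms), on a saturated ring carbon. For the measured compounds named here, the measured steps at this saturated ring carbon, a 1.8-fold higher number from compound 1 to compound 3 (0.25 log units; within the scatter) and a 4.5-fold lower number from compound 1 to compound 2 (0.65 log units; beyond the scatter), were modest at most, and none of the measured compounds carries a carbamoyl group there, so the new group is untested. Compound 4 is therefore expected to stay in the same modest range, and its step of a 1.3-fold higher number from compound 3 to compound 4 (0.10 log units; within the scatter) is estimated to be small. The estimate for compound 4 is 20 nM, with a range from 5 nM to 80 nM.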

Compound 4, half-maximal effective concentration: 18 nM
Estimate against measurement, compound 4: 1.1-fold (0.05 log units) above; low and high end bracket the measured number.
By their numbers in this assay, from the lowest: compound 2; then compounds 1, 3 and 4 (each within the scatter of the next).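

The methyl(1,3-thiazol-2-yl)carbamoyl group shows that a carbamoyl link on this saturated ring carbon is compatible with activity in this assay: with a 1.1-fold higher number from compound 3 to compound 4 (0.05 log units; within the scatter) and a 2.0-fold higher number from compound 1 to compound 4 (0.30 log units; within the scatter), both steps stay within the scatter. Only the (2-chlorobenzyl)oxy group stands apart, with a 9.0-fold higher number from compound 2 to compound 4 (0.95 log units; beyond the scatter), a step beyond the scatter. No evidence is available on what lies behind these steps.

The compounds shown leave open whether the methyl on the carbamoyl nitrogen or the thiazole ring matters. They also leave open how a carboxylic acid or a simple amine would fare on this carbon.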